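The source may hold more compounds than are shown below. What is called first, only, known or untested is meant among the compounds shown, and "the series" means these compounds.

In an ADME assay on DU-145 cells (Homo sapiens) for cytotoxicity, read by MTT assay, with a stated time of 72 h (a lower number here means a stronger inhibitor of growth, a higher number a weaker inhibitor of growth), compound 2 `CCCCNC(=O)C1C(C(=O)O)[C@@H]2CC[C@H]1O2` gives 10000 nM. That places it level with the other two measured compounds: compound 1 `CCCCCCCCCCNC(=O)C1C(C(=O)O)[C@@H]2CC[C@H]1O2` gives 10000 nM, and compound 3 `O=C(O)c1ccc(NC(=O)C2C(C(=O)O)[C@@H]3CC[C@H]2O3)cc1Cl` gives 10000 nM. Compound 4 `O=C(O)CCCNC(=O)C1C(C(=O)O)[C@@H]2CC[C@H]1O2` departs from compound 2 at a single place: carboxy in place of methyl on a saturated chain carbon, three bonds along the chain from an amide-type nitrogen. In words, this is carboxy in place of methyl on a saturated chain carbon, three bonds along the chain from an amide-type nitrogen, or, cut further out, butyl to 3-carboxypropyl. Going by the values given here, only one measured step concerns this chain, no change at the digits printed from compound 1 to compound 2 (within the scatter), and it is hydrogen in place of hexyl on a saturated chain carbon, four bonds along the chain from an amide-type nitrogen. Compound 3, which also carries a carboxy group outside the shared core, gives 10000 nM as well. Among the compounds with values here, nothing measured so far therefore points to a step beyond the scatter in this assay, in either direction. The expected result is no change at the digits printed from compound 2 to compound 4 (within the scatter). For compound 4 the estimate is 10000 nM, with an expected range of 6000 nM to 20000 nM.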

Compound 4, concentration for 50% growth inhibition: 10000 nM
For compound 4 middle estimate and measured number coincide at the digits printed; the measured number falls inside the stated range.
By their numbers in this assay, from the lowest: compounds 1, 2, 3 and 4 (each within the scatter of the next).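

In this assay, carboxy in place of methyl on a saturated chain carbon, three bonds along the chain from an amide-type nitrogen, gives no change at the digits printed from compound 2 to compound 4 (within the scatter) and so adds a group bearing a hydrogen-bond donor to a chain previously seen only as plain alkyl. The larger exchange at the same place, carboxy in place of heptyl, gives no change at the digits printed from compound 1 to compound 4 (within the scatter) and likewise leaves the printed number as it stands. Nothing available accounts for this outcome.

The compounds shown leave open whether an amine or a hydroxyl group at this place would move the number away from that of compound 2, which gives 10000 nM in this assay, by more than the scatter. They also leave open whether an ester or an amide in place of the carboxy would do so.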